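Pyrimidin-5-yl in place of phenyl: half-life notes

This account rests on a few compounds, and the source may have more. Where it says the series, first, only, none or still open, it means among the compounds named here.

Measured in an ADME assay on the whole organism for metabolic stability, with Rattus norvegicus as the target; a lower number here means that the compound disappears faster, a higher number that the compound lasts longer:
- compound 1 `CSCC[C@H](NC(=O)c1ccc(CN(Cc2ccccc2)c2ccccc2)cc1-c1ccccc1C)C(=O)O`: 0.8 h
- compound 2 `CSCC[C@H](NC(=O)c1ccc(CN(Cc2cc(F)cc(F)c2)c2ccccc2)cc1-c1ccccc1C)C(=O)O`: 1.9 h
- compound 3 `CSCC[C@H](NC(=O)c1ccc(CN(Cc2cc(F)cc(F)c2)c2cccnc2)cc1-c1ccccc1C)C(=O)O`: 1 h

Compound 1 and compound 3 lie within the scatter of each other, and the clear gap in the series is a 2.4-fold higher number from compound 1 to compound 2 (0.38 log units; beyond the scatter). Compound 4 `CSCC[C@H](NC(=O)c1ccc(CN(Cc2ccccc2)c2cncnc2)cc1-c1ccccc1C)C(=O)O` has pyrimidin-5-yl in place of phenyl on an amine nitrogen. The closest measured change is pyridin-3-yl in place of phenyl on an amine nitrogen, seen as a 1.9-fold lower number from compound 2 to compound 3 (0.28 log units; within the scatter). The other step concerns a different place and bears little on this one. A small downward move is therefore expected, probably not beyond the scatter. The expected change is a 1.3-fold lower number from compound 1 to compound 4 (0.12 log units; within the scatter). Compound 4 is estimated at 0.6 h, with an expected range of 0.3 h to 1.2 h.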

Compound 4, half-life: 0.5 h
Compound 4: middle estimate off by 1.2-fold (0.08 log units), on the high side, within the range that was stated.
By their numbers in this assay, from the lowest: compounds 4, 1, 3 and 2 (each within the scatter of the next, the first and the last beyond it).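

On the amine nitrogen, pyrimidin-5-yl in place of phenyl gives a 1.6-fold lower number from compound 1 to compound 4 (0.20 log units; within the scatter) in this assay, so this exchange does not separate the two compounds. The position now has a second ring-nitrogen replacement whose step stays within the scatter, this one with phenyl rather than 3,5-difluorophenyl on the saturated chain carbon. No supporting measurement bears on this step.

Still open, going by these compounds, is how pyrimidin-5-yl behaves alongside 3,5-difluorophenyl. Also open, on these data alone, is whether a saturated group such as cyclohexyl on the amine nitrogen would move the half-life beyond the scatter.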